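The source may hold more compounds than are shown below. What is called first, only, known or untested is meant among the compounds shown, and "the series" means these compounds.

Measured compounds:
- compound 1, `Cc1c(OCCCCOc2ccccc2C(=O)O)ccc(C(=O)CC2CCCC2)c1C`: 67.1%
- compound 2, `Cc1c(OCCCCOc2ccccc2C(=O)O)ccc(C(=O)CC2CCCC2)c1O`: 98.8%
- compound 3, `Cc1c(OCCCCOc2ccccc2C(=O)O)ccc(C(=O)CC(C)C)c1C`: 76.2%

All three numbers come from an assay on HEK293 cells for positive allosteric modulation of metabotropic glutamate receptor 2 (Rattus norvegicus), read by thallium flux, with a stated time of 2.5 min; a higher number here means a larger maximal response, a lower number a smaller maximal response. Compound 1 gives the lowest of the three values: compound 3 sits nearest, a number 9.1 percentage points higher from compound 1 to compound 3 (within the scatter), and compound 2 furthest, a number 31.7 percentage points higher from compound 1 to compound 2 (beyond the scatter).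

Compound 4, `Cc1c(OCCCCOc2ccc(C(=O)O)c(Cl)c2)ccc(C(=O)CC2CCCC2)c1C`, has not been measured. Against compound 1 the difference is 4-carboxy-3-chlorophenyl in place of 2-carboxyphenyl on an oxygen on a saturated carbon. Neither measured step touches this part of the molecule: the step to compound 2 alters the hydroxy in place of methyl on an aromatic carbon of the core, and the step to compound 3 alters the isopropyl in place of cyclopentyl on a saturated chain carbon bound to a carbonyl carbon. Both leave the 2-carboxyphenyl end untouched, so they give no direct guidance on moving the carboxy group and adding a chlorine there. With nothing in the series bearing on this change, no step beyond the scatter in this assay is expected in either direction; the estimate therefore stays close to compound 1, with a wide range to reflect the absence of a precedent.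

Compound 4 is expected to give 67%, between 48% and 88%, meaning a number 0.1 percentage points lower from compound 1 to compound 4 (within the scatter).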

Compound 4, largest response reached (reported as percent of maximum), in percent of the reference or control that the assay uses: 61.8%
Beside the measured number, compound 4's estimate is 5.2 percentage points above it; the measured number falls inside the stated range.
By their numbers in this assay, from the lowest: compounds 4, 1 and 3 (each within the scatter of the next, the first and the last beyond it); then compound 2.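

In this assay, among these compounds, the first change at this end of the molecule, 4-carboxy-3-chlorophenyl in place of 2-carboxyphenyl on an oxygen on a saturated carbon, gives a number 5.3 percentage points lower from compound 1 to compound 4 (within the scatter), so the maximal response of compound 1 is kept with this different aryl group. The entering group differs from the leaving one both in where the carboxy group stands and in carrying a chlorine, so this single step cannot divide the result between those two features, which may contribute separately or offset each other. No measurement is available that bears on why the response holds across this change.

The compounds shown leave open whether 4-carboxyphenyl without the chlorine, or a 2-carboxyphenyl carrying a chlorine, would give the same response, and whether a tetrazole or an amide can stand in for the carboxylic acid at this end. They also leave open whether 4-carboxy-3-chlorophenyl keeps its effect on the core bearing the hydroxy group of compound 2, where the response reaches 98.8%, or with the isopropyl group of compound 3.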